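The source may hold more compounds than are shown below. What is called first, only, known or untested is meant among the compounds shown, and "the series" means these compounds.

Working notes on the anilino series.

In a functional assay for inhibition, with Homo sapiens as the target (on this read-out higher numbers stand for weaker inhibition and lower numbers for stronger inhibition), compound 1, `Cc1cc(C)cc(Nc2nccc(-c3ccccn3)n2)c1`, gives 100 nM. Compound 2, `CNc1ccc(Nc2nccc(-c3cccnc3)n2)cc1`, gives 2100 nM in this assay, the higher of the two numbers reported; the gap between compound 1 and compound 2 is beyond the scatter of repeated measurements. Compound 3, `COc1cccc(Nc2nc(C)cc(-c3ccncc3)n2)c1`, returns only a limit in this assay, > 24000 nM, and no number; this is the limit of > 24000 nM in this assay, at which 1 of the 3 values shown sits. Among the compounds with values here, no pair among the three measured compounds differs in a single place, so no single step has yet been isolated.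

Compound 4, `Oc1ccc(Nc2nccc(-c3cccnc3)n2)cc1`, is the next compound for this assay. Relative to compound 2 the change is hydroxy in place of methylamino on an aromatic carbon.

Within the data shown here, nothing among the measured compounds isolates this exchange, and the expectation therefore rests on the value of compound 2 alone. A small step is expected from compound 2 to compound 4, a 1.4-fold higher number from compound 2 to compound 4 (0.15 log units; within the scatter), within or close to the scatter. Compound 4 is estimated at 3000 nM in this assay, with a range from 800 nM to 12000 nM.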

Compound 4, half-maximal inhibitory concentration: 5100 nM
Beside the measured number, compound 4's estimate is 1.7-fold (0.23 log units) below it, within the range that was stated.
By their numbers in this assay, from the lowest: compound 1; then compound 2; then compound 4. At a limit, above all of these: compound 3.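

Within the data shown here, this is the first step that changes only one place. In this assay, hydroxy in place of methylamino on an aromatic carbon, para to a large group, gives a 2.4-fold higher number from compound 2 to compound 4 (0.39 log units; beyond the scatter) and shows that this position responds to the exchange, though only modestly. The two groups match in their counts, each with one hydrogen-bond donor, one hydrogen-bond acceptor and no net charge, and those matching counts did not keep the two values within the scatter. No measurement shown accounts for the size of this step.

As far as these compounds go, one exchange at this carbon gives no trend, and it remains open how an amine, a carboxylic acid or a longer chain placed there would compare with methylamino and hydroxy. Compound 1 and compound 3 each differ from compound 2 and compound 4 in more than one place, and the contribution of the other parts of these structures therefore remains unseparated from that of this position.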